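Amino for nitro on two related dithiole cores

The source may hold more compounds than are shown below. What is called first, only, known or untested is meant among the compounds shown, and "the series" means these compounds.

Measured compounds in a functional assay on SGC-7901 cells (Homo sapiens) for antiproliferative activity, read by MTT assay, with a stated time of 72 h; on this read-out lower numbers stand for stronger inhibition and higher numbers for weaker inhibition:
- compound 1 `COc1ccc(-c2ssc(=O)c2-c2cc(OC)c(OC)c(OC)c2)cc1[N+](=O)[O-]`: 440 nM
- compound 2 `COc1ccc(-c2ssc(=O)c2-c2cc(OC)c(OC)c(OC)c2)cc1N`: 172 nM
- compound 3 `COc1ccc(-c2c(-c3cc(OC)c(OC)c(OC)c3)ssc2=O)cc1[N+](=O)[O-]`: the assay reports only a limit, > 100000 nM

Compound 1 and compound 2 share one core and differ in a single place: amino in place of nitro on an aromatic carbon. In this assay that change gave a 2.6-fold lower number from compound 1 to compound 2 (0.41 log units; beyond the scatter).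

Compound 3 has the same atoms as compound 1 joined differently; the difference between the two cores is not broken down here. Its limit sits at the limit of > 100000 nM in this assay, at which 1 of the 3 values shown sits.

The unmeasured compound 4 `COc1ccc(-c2c(-c3cc(OC)c(OC)c(OC)c3)ssc2=O)cc1N` stands to compound 3 as compound 2 stands to compound 1: amino in place of nitro on an aromatic carbon. The place lines of the two changes read the same word for word, so this is the same kind of change on a different core.

The expected step is a number no higher from compound 3 to compound 4 (the limit leaves the size open), resting on the measured 2.6-fold lower number from compound 1 to compound 2 (0.41 log units; beyond the scatter) and on the limit of compound 3 in this assay. Compound 4 is therefore expected to give about 100000 nM, with a likely range from 30000 nM to 300000 nM, and it is expected that this assay may again report only a limit.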

Compound 4, half-maximal inhibitory concentration: > 100000 nM
Compound 4 was reported as a limit; the forecaster's own chance of this, stated with the estimate: 65%; the middle value sits exactly at the limit.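

Compound 3 and compound 4 are each reported only as a limit, so no step can be read from one to the other: the limit of > 100000 nM in this assay, at which 2 of the 4 values shown sit.

What the compounds shown leave open is whether amino in place of nitro on an aromatic carbon changes the number at all on the core of compound 3, as it does on the core of compound 1.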